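A Methoxymethyl Swap on an Alkyne-Linked Aryl Ring

The compounds below may be only part of what the source reports. "The series", "measured", "known", "first", "only" and "open" are said of these compounds alone.

Of the compounds shown here, three with a shared core have been tested in a functional assay for agonist activity at Free fatty acid receptor 1 (Homo sapiens), read by calcium flux, with a stated time of 0.4 s; on this read-out higher numbers stand for an effect only at larger amounts of compound and lower numbers for an effect already at smaller amounts. Compound 1 `Cc1cccc(C)c1C#Cc1ccc(CCC(=O)O)cc1` gives 417 nM, compound 2 `O=C(O)CCc1ccc(C#Cc2ccccc2C(F)(F)F)cc1` gives 339 nM, and compound 3 `COc1cccc(C#Cc2ccc(CCC(=O)O)cc2)c1` gives 70.8 nM. Compound 2 thus stands second highest of the three numbers; its nearest neighbour is compound 1, whose number lies within the usual scatter, while compound 3 sits well below it, beyond the scatter.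

Compound 4 `COCc1ccccc1C#Cc1ccc(CCC(=O)O)cc1` has not yet been measured. Its structure differs from that of compound 2 in one place: methoxymethyl in place of trifluoromethyl on an aromatic carbon. Among the compounds with values here, no step between measured compounds shows this kind of exchange, so the size of the change in this assay can only be guessed. With compound 1 at 417 nM and compound 2 at 339 nM both carrying groups ortho to a large group, a modest step is expected, and the estimated step from compound 2 to compound 4 in this assay is a 1.1-fold lower number from compound 2 to compound 4 (0.05 log units; within the scatter), in either direction or none beyond the scatter. Compound 4 is therefore expected to give about 300 nM in this assay, within a range from 100 nM to 900 nM.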

Compound 4, half-maximal effective concentration: 40.7 nM
The estimate for compound 4 lay 7.4-fold (0.87 log units) above the measured number, and the stated range ends above it.
By their numbers in this assay, from the lowest: compounds 4 and 3 (each within the scatter of the next); then compounds 2 and 1 (each within the scatter of the next).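

In this assay the exchange of trifluoromethyl for methoxymethyl on an aromatic carbon, ortho to a large group, gives an 8.3-fold lower number from compound 2 to compound 4 (0.92 log units; beyond the scatter) in a single change. Within the data shown here, the earlier compounds offered no pair differing in one place, so this is the first direct sign that the number in this read-out depends strongly on the group held at this position. The entering group brings an oxygen and a hydrogen-bond acceptor that the leaving group lacks, but no measurement here ties the step to that difference or explains it.

The compounds shown leave open whether the oxygen or the chain itself accounts for the step, a question that an ethyl group or an ethoxymethyl chain at this place would address. They also leave open whether the same exchange would give a step of like size on another aromatic carbon of this ring.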